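A few compounds are considered here, and "the series" means these few. Any claim that something is new, unique, unknown or untested is made for them only; others in the source may bear on it.

Measured compounds:
- compound 1, `Cc1ccc(NC(=S)OCCNC(=O)C(C)(C)Oc2ccc(Cl)cc2)cc1` — in an ADME assay for pharmacokinetics, in phosphate buffer, tested at 60 uM (a lower number here means that the compound disappears faster, a higher number that the compound lasts longer), compound 1 gives 0.0167 h
- compound 2, `CC(C)(Oc1ccc(Cl)cc1)C(=O)Oc1ccc(C(N)=S)cc1` — in this assay compound 2 gives 0.0933 h

Of the two numbers measured in this assay, compound 1 stands lowest; the nearest value belongs to compound 2, whose number is higher by a margin that lies beyond the scatter. Going by the values given here, the two compounds differ in more than one place, so their values are simply taken as they stand, with no step drawn between them.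

Compound 3, `CC(C)(Oc1ccc(Cl)cc1)C(=O)NCCOC(=S)Nc1ccc([N+](=O)[O-])cc1Cl`, has not yet been measured. Against compound 1 it shows one change: 2-chloro-4-nitrophenyl in place of 4-methylphenyl on an amide-type nitrogen. The shared core is otherwise kept. Among the compounds with values here, no measured pair carries the same change, so there is no step from which a direction could be read off.

The expectation for compound 3 in this assay is therefore anchored on the value of compound 1, 0.0167 h, with the step of a 1.1-fold lower number from compound 1 to compound 3 (0.05 log units; within the scatter) expected to stay within the scatter, if anything leaning slightly lower. Compound 3 is estimated at 0.015 h, with a range from 0.006 h to 0.04 h.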

Compound 3, half-life: 0.0283 h
Compound 3: the middle estimate sits 1.9-fold (0.28 log units) below what was measured; the measured number falls inside the stated range.
By their numbers in this assay, from the lowest: compounds 1 and 3 (each within the scatter of the next); then compound 2.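

At this position, on an amide-type nitrogen whose other neighbour is the thiocarbonyl carbon, the series now has its first readable step: in this assay, 2-chloro-4-nitrophenyl in place of 4-methylphenyl gives a 1.7-fold higher number from compound 1 to compound 3 (0.23 log units; within the scatter). Two aromatic groups that differ in their atoms, in their size and in the hydrogen-bond acceptors counted for them therefore do not separate in this read-out, and this one change leaves the half-life where the scatter cannot tell it from that of compound 1. No measurement shown here explains this outcome or ties it to any feature of either group.

The chlorine and the nitro group entered together, so a 2-chlorophenyl or a 4-nitrophenyl group alone would be needed to tell whether either has any separate bearing on the number, and a single step cannot show whether they offset each other. From the compounds shown here alone, it also remains open whether a different kind of group on this nitrogen, such as a plain alkyl chain or an aminophenyl group, would move the half-life beyond the scatter, or whether the number is set elsewhere in the shared core.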